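Thiophene in place of fluorophenyl on a shared core

A few compounds are considered here, and "the series" means these few. Any claim that something is new, unique, unknown or untested is made for them only; others in the source may bear on it.

Of the compounds shown here, three built on one shared core have been tested so far in a functional assay on NCI-H522 cells (Homo sapiens) for inhibition, read by sulforhodamine B assay, with a stated time of 48 h, tested at 10 uM; a higher number here means more inhibition at the concentration tested (going by the name of the read-out), a lower number less inhibition. Compound 1 `Brc1cn2ccnc2c(-c2ccc3ncn(C4CCCCC4)c3c2)n1` gives 16.2%, compound 2 `c1ccc2c(-c3cn4ccnc4c(-c4ccc5ncn(C6CCCCC6)c5c4)n3)cccc2c1` gives 19.3%, and compound 3 `Fc1ccc(-c2cn3ccnc3c(-c3ccc4ncn(C5CCCCC5)c4c3)n2)cc1` gives 15.5%. Compound 3 thus holds the lowest of the three numbers, but its gap to the nearest, a number 0.7 percentage points lower from compound 1 to compound 3 (within the scatter), and to the furthest, a number 3.8 percentage points lower from compound 2 to compound 3 (within the scatter), both lie within the usual scatter, so the three compounds cannot be told apart on this read-out. Compound 4 `c1cn2cc(-c3ccsc3)nc(-c3ccc4ncn(C5CCCCC5)c4c3)c2n1` has not yet been measured. It differs from compound 3 in one place: thiophen-3-yl in place of 4-fluorophenyl on an aromatic carbon. The measured steps that bear on this exchange are those in which the same position was varied, a number 3.1 percentage points higher from compound 1 to compound 2 (within the scatter) and a number 0.7 percentage points lower from compound 1 to compound 3 (within the scatter), and neither reached beyond the scatter. Three different groups at this position have so far left this assay unchanged, so no step beyond the scatter is expected for a thiophen-3-yl either. Compound 4 is therefore expected to give 16%, with a range from 7% to 27%. This estimate means a step of a number 0.5 percentage points higher from compound 3 to compound 4 (within the scatter), expected to remain within the scatter.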

Compound 4, a percentage reported as inhibition, at one concentration (the size of the read-out at that concentration, not a potency): 10.3%
Beside the measured number, compound 4's estimate is 5.7 percentage points above it; low and high end bracket the measured number.
By their numbers in this assay, from the lowest: compounds 4, 3, 1 and 2 (each within the scatter of the next).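

Among the compounds shown here, the thiophen-3-yl, a five-membered aromatic ring with one sulfur, is the first group at this position that is not a bromo or a six-membered or fused carbon ring, and it too gives no readable change in this assay: the steps are a number 5.2 percentage points lower from compound 3 to compound 4 (within the scatter) and a number 5.9 percentage points lower from compound 1 to compound 4 (within the scatter) and a number 9 percentage points lower from compound 2 to compound 4 (within the scatter) in turn. These steps are larger than the earlier ones at this position, yet all stay inside the scatter, so the four groups still cannot be ranked and a hetero atom in this ring has shown no effect of its own here. Nothing measured here explains why the position makes so little difference.

Going by these compounds, whether any group on this aromatic carbon can move the number beyond the scatter stays open. An amine or a carboxylic acid in this place would test that with a group of a different kind from these four.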